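From Ester to Acid: Estimating Stability of Compound 4

The source may report more compounds than this note shows. Statements on the series, on what has been measured and on what is new or still open speak of the compounds shown alone.

Compound 1, `COC(=O)c1ccc(-c2nnn(CC(=O)C(C)Oc3ccc(Oc4ccc(Cl)cc4)cc3)n2)cc1`, gives < 5% in an ADME assay on S9 fraction from liver (Rattus norvegicus) for metabolic stability, read by LC-MS, using NADPH, with a stated time of 30 min; a higher number here means that more of the compound is left, a lower number that less of the compound is left; that figure is a limit of the assay, as the limit of < 5% in this assay, at which 1 of the 3 values shown sits, states.
Compound 2, `COC(=O)c1ccc(-c2nnn(CC(=O)C(C)Oc3ccc(Oc4ccc(C(F)(F)F)cc4)cc3)n2)cc1`, gives 15% in this assay.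
Compound 3, `COC(=O)c1ccc(-c2nnn(CC(=O)C(C)Oc3ccc(-c4ccccc4)cc3)n2)cc1`, gives 21% in this assay.

Compound 3 and compound 2 lie within the scatter of each other, since a number 6 percentage points higher from compound 2 to compound 3 (within the scatter). The steps of a number at least 10 percentage points higher from compound 1 to compound 2 (that floor lies within the scatter) and a number at least 16 percentage points higher from compound 1 to compound 3 (beyond the scatter) both change the aryl ether end of the shared core. Compound 4, `CC(Oc1ccc(-c2ccccc2)cc1)C(=O)Cn1nnc(-c2ccc(C(=O)O)cc2)n1`, differs from compound 3 by hydrogen in place of methyl on an oxygen next to a carbonyl group. Going by the values given here, no measured step touches that place, so the size and direction of the expected step of a number 14 percentage points higher from compound 3 to compound 4 (beyond the scatter) rest on little. Compound 4 is therefore estimated at 35%, within 10% to 70%.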

Compound 4, percent of the compound remaining: 30%
Compound 4: middle estimate off by 5 percentage points, on the high side; measured number inside the range.
By their numbers in this assay, from the lowest: compounds 2, 3 and 4 (each within the scatter of the next, the first and the last beyond it). At a limit, below all of these: compound 1.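

The change from methoxycarbonyl to carboxy, the first at this place, gives a number 9 percentage points higher from compound 3 to compound 4 (within the scatter) in this assay. Hydrogen and methyl on this oxygen therefore cannot be told apart here, which the earlier compounds, all methyl esters, could not show. Nothing known here explains the result.

Open, going by these compounds, is how an amide or an ethyl ester in this place would read in this assay. Also open, on these data alone, is whether carboxy in place of methoxycarbonyl would read the same on compound 1 and on compound 2.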